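Swapping a Chain-End Group in a Whole-Animal Inhibition Test

A few compounds are considered here, and "the series" means these few. Any claim that something is new, unique, unknown or untested is made for them only; others in the source may bear on it.

Measured so far:
- compound 1 `Cn1c(-c2ccccc2C(F)(F)F)nnc1C12CCC(CCCC(C)(F)F)(CC1)CC2`, which in a functional assay on the whole organism (strain ICR) for inhibition, with Mus musculus as the target, with a stated time of 4 h, at a dose of 10 mg/kg by the oral route (on this read-out higher numbers stand for more inhibition at the one dose given (going by the name of the read-out) and lower numbers for less inhibition), gives 99%
- compound 2 `CCS(=O)(=O)CCCCC12CCC(c3nnc(-c4ccccc4C(F)(F)F)n3C)(CC1)CC2`, which in this assay gives 90%

For the measured compounds named here, compound 2 holds the lower of the two numbers, yet its only neighbour is compound 1, and the step of a number 9 percentage points lower from compound 1 to compound 2 (within the scatter) sits within the usual scatter, so the two compounds cannot be told apart on these data. Going by the values given here, the only measured step is that one, and it touches the same chain end that is now changed again.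

Compound 3 `CC(O)CCCC12CCC(c3nnc(-c4ccccc4C(F)(F)F)n3C)(CC1)CC2` arises from compound 2 by the change (1-hydroxyethyl in place of (ethylsulfonyl)methyl on a saturated chain carbon, three bonds along the chain from a saturated ring carbon). The step from compound 1 to compound 2 already showed that exchanging the group at this chain end left the read-out in this assay essentially unchanged, so a further exchange at the same spot is expected to move the number little, if at all, beyond the scatter.

On that basis compound 3 is expected to give 88% in this assay, with a range from 70% to 99%. The expected step is therefore a number 2 percentage points lower from compound 2 to compound 3 (within the scatter).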

Compound 3, a percentage reported as inhibition, in the whole organism at one dose (the size of the read-out at that dose, not a potency): 97%
Compound 3: middle estimate off by 9 percentage points, on the low side; the range from low to high includes it.
By their numbers in this assay, from the lowest: compounds 2, 3 and 1 (each within the scatter of the next).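

In this assay, the exchange of (ethylsulfonyl)methyl for 1-hydroxyethyl gives a number 7 percentage points higher from compound 2 to compound 3 (within the scatter), and the exchange of 1,1-difluoroethyl for 1-hydroxyethyl gives a number 2 percentage points lower from compound 1 to compound 3 (within the scatter), so all three chain-end groups now stand within the scatter of one another. This extends the earlier finding: the position on a saturated chain carbon, three bonds along the chain from a saturated ring carbon, has now also taken a group with one hydrogen-bond donor, where (ethylsulfonyl)methyl has none, without a step beyond the scatter. No measurement at hand explains why these exchanges leave the number within the scatter.

The compounds shown leave open whether an amine, a carboxylic acid or a longer chain at this same place would also stay within the scatter, or whether one of them would finally produce a clear step. Since this assay reports the size of the effect at one dose and not a potency, these three compounds also leave open whether they would still match one another at other doses.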